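Ethyl(methyl)amino in place of methoxy: notes on compound 4

The compounds below may be only part of what the source reports. "The series", "measured", "known", "first", "only" and "open" are said of these compounds alone.

Values so far in a functional assay on the whole organism with Rattus norvegicus as the target (on this read-out higher numbers stand for an effect only at larger amounts of compound and lower numbers for an effect already at smaller amounts), for three compounds:
- compound 1 `CCOC(=O)C(=O)Nc1cccc(OC)c1C#N` gives 55.5 mg/kg
- compound 2 `CCOC(=O)C(=O)Nc1ccc(N(C)C)cc1C#N` gives 2.4 mg/kg
- compound 3 `CCOC(=O)C(=O)Nc1cccc(N)c1C#N` gives 0.07 mg/kg

Compound 1 has the highest number of the three, and both other compounds lie beyond the scatter from it. The step under study leads to compound 4 `CCOC(=O)C(=O)Nc1cccc(N(C)CC)c1C#N` and is ethyl(methyl)amino in place of methoxy on an aromatic carbon with the rest of the core of compound 1 unchanged.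

Among the compounds with values here, one measured step bears on it directly. Amino in place of methoxy gave a 790-fold lower number from compound 1 to compound 3 (2.90 log units; beyond the scatter) in this assay and that step is large. Within the data shown here, compound 3 carries plain amino, however, while compound 4 carries ethyl(methyl)amino, and no measured pair shows how much of that step remains once the nitrogen is substituted. Compound 2 also bears a substituted amino group but differs from compound 1 in more than one way. Compound 2 gives 2.4 mg/kg and so lies between compound 1 and compound 3 on the numbers.

A step in the same direction, beyond the scatter but smaller than the amino step, is therefore expected in this assay for this change. The estimated change is a 19-fold lower number from compound 1 to compound 4 (1.27 log units; beyond the scatter) towards the lower numbers. Compound 4 is estimated at 3 mg/kg within an expected range of 0.3 mg/kg to 25 mg/kg for now.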

Compound 4, dose for half-maximal effect: 0.5 mg/kg
Estimate against measurement, compound 4: 6.0-fold (0.78 log units) above; low and high end bracket the measured number.
By their numbers in this assay, from the lowest: compound 3; then compound 4; then compound 2; then compound 1.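

In this assay, ethyl(methyl)amino in place of methoxy on the aromatic carbon ortho to a cyano group gives a 110-fold lower number from compound 1 to compound 4 (2.05 log units; beyond the scatter), so a large step remains with both hydrogens of the amino group replaced by carbon chains. The substituted nitrogen does not match plain amino, however: ethyl(methyl)amino in place of amino gives a 7.1-fold higher number from compound 3 to compound 4 (0.85 log units; beyond the scatter), a modest step that is still beyond the scatter, and compound 3 keeps the lowest number among the compounds shown. Nothing available accounts for the size of either step.

The compounds shown do not separate the contributions of the methyl and ethyl groups on this nitrogen, and a methylamino or ethylamino group at this position would be needed to place the single substitution between amino and ethyl(methyl)amino. Also open, from the compounds shown here alone, is how the numbers would respond at the same position to a longer chain on the nitrogen, such as dipropylamino, or to a cyclic amine such as pyrrolidine.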